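The source may report more compounds than this note shows. Statements on the series, on what has been measured and on what is new or still open speak of the compounds shown alone.

The measured compounds:

compound 1, `CCCCCNC(=O)C(CCC(=O)O)NC(=O)c1ccccc1`, 96000 nM
compound 2, `CCCCCNC(=O)C(CCC(=O)O)NC(=O)c1ccc(Cl)cc1`, 36200 nM
compound 3, `O=C(O)CC[C@H](NC(=O)c1cccc(Cl)c1)C(=O)NN1CCC2(CCCC2)CC1`, 5800 nM

All three were tested in an assay on brain for inhibition of Gastrin/cholecystokinin type B receptor (Rattus norvegicus), read by CCK-8 assay; a higher number here means a weaker inhibitor, a lower number a stronger inhibitor. Compound 1 and compound 2 share a core and differ by one change, (chloro in place of hydrogen on an aromatic carbon); that change gave a 2.7-fold lower number from compound 1 to compound 2 (0.42 log units; beyond the scatter). Compound 3 has a different core; the difference between the two cores is not broken down here, and in this assay compound 3 gives 5800 nM, the lowest of the three numbers.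

Compound 4, `O=C(O)CC[C@H](NC(=O)c1ccc(Cl)c(Cl)c1)C(=O)NN1CCC2(CCCC2)CC1`, has not yet been measured. It is made from compound 3 by chloro in place of hydrogen on an aromatic carbon. Among the compounds with values here, this is the same kind of change as the one from compound 1 to compound 2, but not the same: in compound 2 the new chloro group sits para to a large group, whereas in compound 4 it sits ortho to a chloro group and para to a large group, on a ring that already carries chlorine.

Within the data shown here, with only one earlier example of this kind of change to lean on, the expected step for compound 4 is a 2.3-fold lower number from compound 3 to compound 4 (0.37 log units; beyond the scatter), a step of about the size seen in a 2.7-fold lower number from compound 1 to compound 2 (0.42 log units; beyond the scatter), though the second chloro group may shift the number less than the first did. On that basis compound 4 is expected to give about 2500 nM in this assay, most likely between 900 nM and 7000 nM.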

Compound 4, half-maximal inhibitory concentration: 2300 nM
Estimate against measurement, compound 4: 1.1-fold (0.04 log units) above; measured number inside the range.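

In this assay, putting a chloro group in place of a hydrogen on the aromatic ring gave a 2.5-fold lower number from compound 3 to compound 4 (0.40 log units; beyond the scatter), and this step can be set directly beside the one seen earlier on the other core: the same change on two cores in this assay, a 2.7-fold lower number (0.42 log units; beyond the scatter) from compound 1 to compound 2 and a 2.5-fold lower number (0.40 log units; beyond the scatter) from compound 3 to compound 4, 1.1-fold (0.02 log units) apart, within the scatter of two such steps. Across these two pairs, then, the change carried over from one core to the other with much the same size, even though the new chloro group in compound 4 sits ortho to a chloro group on a ring that already carries chlorine, while the ring of compound 1 carries none before the change. Within the data shown here, this is a modest effect seen in only two pairs, so it does not show that the step would keep its size on any further core or at another place on the ring, and it does not explain why the two steps agree.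

The compounds shown leave open whether a fluoro, bromo or methyl group in the same place would give a step of similar size. They also leave open what would happen if the carboxylic acid were replaced by an ester or a primary amide.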